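The source may hold more compounds than are shown below. What is called first, only, known or untested is meant among the compounds shown, and "the series" means these compounds.

Compound 1 `CCN(CC)c1ccc(-c2cccc(C(F)(F)F)c2)nn1`: in a functional assay on NCI-H727 cells (Homo sapiens) for antiproliferative activity, with a stated time of 48 h (a higher number here means a weaker inhibitor, a lower number a stronger inhibitor), compound 1 gives > 25000 nM, a limit of the assay rather than a number.
Compound 2 `CCN(CC)c1ccc(-c2cccc(C#N)c2)nn1`: compound 2 gives > 25000 nM, likewise only a limit.

Compound 1 therefore stands at a limit here, with no exact number. The two values shown both sit at the limit of > 25000 nM in this assay, at which 2 of the 2 values shown sit. Compound 3 `FC(F)(F)c1cccc(-c2ccc(Oc3ccccc3)nn2)c1` differs from compound 1 by phenoxy in place of diethylamino on an aromatic carbon. Within the data shown here, the only measured step, a step that the two limits leave unreadable from compound 1 to compound 2, concerns a different group and cannot be read in size. Among the measured compounds shown here, no measured step covers the present change, so no direction can be drawn for this assay; a weak result is expected. Compound 3 is estimated at 25000 nM, between 8000 nM and 60000 nM, which means an expected step of a number no higher from compound 1 to compound 3 (the limit leaves the size open).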

Compound 3, half-maximal inhibitory concentration: > 25000 nM
Compound 3 was reported as a limit; the forecaster's own chance of this, stated with the estimate: 70%; the middle value sits exactly at the limit.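

Compound 1 and compound 3 both stand at a limit in this assay, so the step between them cannot be read: the limit of > 25000 nM in this assay, at which 3 of the 3 values shown sit.

Which change to the shared core, if any, would give an exact number in this assay stays open.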